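Removing the Ring Methyl From Compound 1

A few compounds are considered here, and "the series" means these few. Any claim that something is new, unique, unknown or untested is made for them only; others in the source may bear on it.

Compound 1 `COc1ccccc1/C=c1\c(=O)[nH]/c(=C/c2cccc(Cl)c2Cl)c(=O)n1C` was tested in a functional assay on HeLa cells (Homo sapiens) for cytotoxicity, read by CCK-8 assay, with a stated time of 72 h (on this read-out higher numbers stand for weaker inhibition and lower numbers for stronger inhibition), where compound 1 gives 200 nM. Of the two compounds with a numerical result it carries the lowest number. Its nearest neighbour is compound 2 `COc1ccccc1/C=c1\c(=O)[nH]/c(=C/c2ccccc2Cl)c(=O)n1C`, which gives 300 nM in this assay; the step of a 1.5-fold higher number from compound 1 to compound 2 (0.18 log units; within the scatter) goes with hydrogen in place of chloro on an aromatic carbon and stays within the scatter. A third member of the series, compound 3 `COc1ccccc1/C=c1/[nH]c(=O)/c(=C\c2ccccc2OC)n(C)c1=O`, was reported as "not active" (no number reported) in this assay, with no number given.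

Compound 4 `COc1ccccc1/C=c1/[nH]c(=O)/c(=C\c2cccc(Cl)c2Cl)[nH]c1=O` has not yet been measured. It differs from compound 1 by hydrogen in place of methyl on an aromatic nitrogen. Going by the values given here, no measured step touches this position: the only step in hand, a 1.5-fold higher number from compound 1 to compound 2 (0.18 log units; within the scatter), concerns a chloro on an aromatic carbon, not the methyl on the aromatic nitrogen, and it was small. Nothing in the series therefore points to a direction. The expected step is a 1.5-fold higher number from compound 1 to compound 4 (0.18 log units; within the scatter), no larger than the scatter, with a wide range to allow for the absence of any comparable step. The result for compound 3 shows that a number may also fail to appear. Compound 4 is expected to give 300 nM in this assay, estimated between 80 nM and 1500 nM.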

Compound 4, half-maximal inhibitory concentration: "not active" (no number reported)
Compound 4 has no reported number here; the estimate stays without a comparison.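

Going by these compounds alone, compound 4, like compound 3, was reported without a number in this assay, so no step from compound 1 to compound 4 can be read. No measured evidence bears on this result. The compounds shown leave open how much weaker compound 4 is than compound 1, and whether removing the methyl has the same outcome in compound 2.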